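A Pyrimidin-2-yl in Place of the 1,2-Oxazol-4-yl

This account rests on a few compounds, and the source may have more. Where it says the series, first, only, none or still open, it means among the compounds named here.

Compound 2 `c1ccc(-c2cnoc2)c(NCC2=NCCN2)c1` carries a 1,2-oxazol-4-yl group on an aromatic carbon of its shared core. In a functional assay for activation of Alpha-1D adrenergic receptor (Homo sapiens) (a higher number here means that more compound is needed for the effect, a lower number that less compound is needed), compound 2 gives only a limit, < 100000 nM, and not a number. Compound 1 `c1csc(-c2ccccc2NCC2=NCCN2)c1` carries thiophen-2-yl at that place, and in this assay compound 1 gives 18.2 nM. Compound 3 `Cc1noc(-c2ccccc2NCC2=NCCN2)n1` carries 3-methyl-1,2,4-oxadiazol-5-yl there; in this assay compound 3 gives only a limit, < 5020 nM. The step that the limit leaves unreadable from compound 1 to compound 2 cannot be read because of the limit of < 100000 nM in this assay, at which 1 of the 3 values shown sits. The step that the limit leaves unreadable from compound 1 to compound 3 likewise cannot be read because of the limit of < 5020 nM in this assay, at which 1 of the 3 values shown sits, and the step that the two limits leave unreadable from compound 2 to compound 3 is hidden by both limits together. Compound 4 `c1cnc(-c2ccccc2NCC2=NCCN2)nc1` differs from compound 2 in one place: pyrimidin-2-yl in place of 1,2-oxazol-4-yl on an aromatic carbon. Among the compounds with values here, no readable step bears on this change, so neither direction nor size can be drawn from the measured compounds; the only firm number among them is the value of compound 1. Compound 4 is therefore expected, with wide uncertainty, near 1000 nM, between 30 nM and 30000 nM. The expected step is a step that the limit leaves unreadable from compound 2 to compound 4, stated as an estimate only.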

Compound 4, half-maximal effective concentration: 81.3 nM
Compound 4: middle estimate off by 12-fold (1.09 log units), on the high side, and the stated range covers the measured number.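

With compound 4, a second group at this place on the shared core gives a number and not just a limit, so two groups can now be compared directly in this assay. Pyrimidin-2-yl in place of thiophen-2-yl gives a 4.5-fold higher number from compound 1 to compound 4 (0.65 log units; beyond the scatter), so a six-membered aromatic ring with 2 hetero atoms needs more compound than thiophen-2-yl, but the step is only modest. Compound 2 and compound 3 give only limits, and their steps to compound 4 cannot be read.

The two groups with numbers differ in both ring size and hetero atoms, so the compounds shown cannot separate these two differences. On these data alone, how a plain phenyl or a pyridin-2-yl group would behave at this place remains open, and either would help to separate them.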